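Replacing Dimethylamino with Methylsulfanyl on a Shared Nucleoside Core

The source may hold more compounds than are shown below. What is called first, only, known or untested is meant among the compounds shown, and "the series" means these compounds.

Measured so far:
- Compound 1 `CN(C)c1nc(N)c2ncn([C@@H]3C[C@@H](O)[C@H](CO)O3)c2n1` gives 125 uM in a functional assay on Raji cells (Homo sapiens); a lower number here means a stronger inhibitor, a higher number a weaker inhibitor.
- Compound 2 `CNc1nc(Br)nc2c1ncn2[C@@H]1C[C@@H](O)[C@H](CO)O1` gives 80 uM in this assay.
- Compound 3 `CN(C)c1nc(Br)nc2c1ncn2[C@@H]1C[C@@H](O)[C@H](CO)O1` reaches only the limit > 300 uM in this assay, so no number is known for it.

Compound 1 and compound 2 lie within the usual scatter of each other. Among the measured compounds shown here, the single measured step, an at least 3.7-fold higher number from compound 2 to compound 3 (0.57 log units; beyond the scatter), concerns a methyl on a nitrogen and touches a different place than the change now in view. Compound 4 `CSc1nc(N)c2ncn([C@@H]3C[C@@H](O)[C@H](CO)O3)c2n1` differs from compound 1 by methylsulfanyl in place of dimethylamino on an aromatic carbon. For the measured compounds named here, no measured step bears on this exchange, so no shift beyond the scatter is expected; compound 4 is estimated at 125 uM (range 40 uM to 300 uM), an expected step of no change at the digits printed from compound 1 to compound 4 (within the scatter).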

Compound 4, concentration for 50% inhibition: 107 uM
Estimate against measurement, compound 4: 1.2-fold (0.07 log units) above; the measured number falls inside the stated range.
By their numbers in this assay, from the lowest: compounds 2, 4 and 1 (each within the scatter of the next). At a limit, above all of these: compound 3.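

In this assay, methylsulfanyl takes the place of dimethylamino on this aromatic carbon between two ring nitrogen atoms with a 1.2-fold lower number from compound 1 to compound 4 (0.07 log units; within the scatter), so the two groups cannot be told apart here. Among the compounds shown here, this is the first sign that this position accepts a sulfur-linked group as well as a nitrogen-linked one. Unlike compound 3, compound 4 gives a measured number rather than a limit: the limit of > 300 uM in this assay, at which 1 of the 4 values shown sits.

On these data alone, what remains open is how a hydroxyl group or a longer chain such as butylsulfanyl would fare on this carbon.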